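The source may report more compounds than this note shows. Statements on the series, on what has been measured and on what is new or still open speak of the compounds shown alone.

Measured compounds:
compound 1, `O=C(O)/C(S)=C/c1c[nH]c2ccc(I)cc12`: 100 nM
compound 2, `O=C(O)/C(S)=C/c1c[nH]c2c(I)cccc12`: 90 nM

Both compounds were run in an assay on isolated protein for inhibition of Calpain-1 catalytic subunit (Sus scrofa), read by FRET; on this read-out higher numbers stand for weaker inhibition and lower numbers for stronger inhibition. Compound 1 gives 100 nM and compound 2 gives 90 nM; compound 2 holds the lowest of the two numbers, but its gap to compound 1 lies within the scatter, so the two stand level and nothing separates them. Each carries an iodo group, set at a different aromatic carbon of the shared core.

Compound 3, `O=C(O)/C(S)=C/c1c[nH]c2c(Cl)cccc12`, has not yet been measured in this assay. It differs from compound 2 in one place: chloro in place of iodo on an aromatic carbon. Going by the values given here, no measured pair shows what exchanging one halogen for another does here, so this step has no precedent. With compounds 1 and 2 level at the same number, the series gives no lean in either direction; the expectation below is therefore held loosely. Compound 3 is expected to give 200 nM in this assay, within a range from 70 nM to 600 nM. The step of a 2.2-fold higher number from compound 2 to compound 3 (0.35 log units; beyond the scatter) is estimated as a modest loss, one that may still fall within the scatter.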

Compound 3, half-maximal inhibitory concentration: 10 nM
Compound 3: the middle estimate sits 20-fold (1.30 log units) above what was measured, and the stated range ends above it.
By their numbers in this assay, from the lowest: compound 3; then compounds 2 and 1 (each within the scatter of the next).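

In this assay, chloro in place of iodo on this aromatic carbon, ortho to a fused ring, gives a 9.0-fold lower number from compound 2 to compound 3 (0.95 log units; beyond the scatter), beyond the scatter, so the read-out depends on which halogen sits here. Compound 1 and compound 2 showed only that the two iodo placements stand level; this step adds that a single exchange of halogen at one of those carbons can separate compounds where moving iodo did not. The exchange swaps one heavy atom for one heavy atom, with no ring, hydrogen-bond donor, hydrogen-bond acceptor or net charge on either side, and no measurement at hand explains the difference.

From the compounds shown here alone, whether fluoro, bromo or a methyl group on this carbon would read closer to chloro or to iodo stays open, since two substituents cannot define a trend. Also open is whether chloro would bring a similar step on the aromatic carbon that carries iodo in compound 1, as the compounds shown include no pair that tests this.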